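Methyl Substitution Tested Against a Cytotoxicity Limit

This account rests on a few compounds, and the source may have more. Where it says the series, first, only, none or still open, it means among the compounds named here.

Of the compounds shown here, three built on a shared core have been measured in a functional assay on RKO cells (Homo sapiens) for cytotoxicity, read by resazurin assay, with a stated time of 72 h; a lower number here means a stronger inhibitor, a higher number a weaker inhibitor. Compound 1 `Cc1cn(-c2csc(Nc3ccc(Br)cc3)n2)c(C)n1` gives 45000 nM in this assay. For compound 3 `Cc1nccn1-c1csc(Nc2ccc(Br)cc2)n1` this assay reports only a limit, > 100000 nM. For compound 2 `Cc1nccn1-c1csc(Nc2cccc(Br)c2)n1` the result in this assay is likewise a limit, > 100000 nM. Compound 2 and compound 3 contain the same atoms joined differently, and the difference between the two cores is not broken down here.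

Compound 1 differs from compound 3 by methyl in place of hydrogen on an aromatic carbon, and this change gave an at least 2.2-fold lower number from compound 3 to compound 1 (0.34 log units; beyond the scatter). The step is known only as a lower bound because compound 3 sits at the limit of > 100000 nM in this assay, at which 2 of the 3 values shown sit.

Compound 4 `Cc1cn(-c2csc(Nc3cccc(Br)c3)n2)c(C)n1` has not yet been measured. It differs from compound 2 by methyl in place of hydrogen on an aromatic carbon, the same change that separates compound 1 from compound 3, at the same place on the ring. Resting on that single measured step, compound 4 is expected to come out near 60000 nM in this assay, with an estimated range from 25000 nM to 150000 nM. The expected step is an at least 1.6-fold lower number from compound 2 to compound 4 (0.22 log units; that floor lies within the scatter). Since compound 2 is known only as a limit, the result for compound 4 may itself be reported as a limit.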

Compound 4, half-maximal inhibitory concentration: > 100000 nM
Compound 4 gave a limit, no number; the forecaster's own chance of this, stated with the estimate: 45%; middle value at least 1.6-fold (0.22 log units) from the limit.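

In this assay compound 4 gives > 100000 nM as a limit and not a number. Going by these compounds alone, compound 2 is also a limit, so no step between compound 2 and compound 4 can be read, and both stand at: the limit of > 100000 nM in this assay, at which 3 of the 4 values shown sit. The compounds shown leave open whether methyl in place of hydrogen on an aromatic carbon changes the number at all when going from compound 2 to compound 4.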